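Swapping the aryl ketone substituent in a trimethoxyphenyl pyrazole chalcone

This account rests on a few compounds, and the source may have more. Where it says the series, first, only, none or still open, it means among the compounds named here.

Measured compounds:
compound 1 `COc1cc(-c2cc(/C=C/C(=O)c3ccc(N)cc3)[nH]n2)cc(OC)c1OC`: 1860 nM
compound 2 `COc1ccc(C(=O)/C=C/c2cc(-c3cc(OC)c(OC)c(OC)c3)n[nH]2)cc1`: 1810 nM

In a functional assay on SN12C cells (Homo sapiens) for inhibition, read by sulforhodamine B assay, with a stated time of 48 h (a higher number here means a weaker inhibitor of growth, a lower number a stronger inhibitor of growth), compound 2 gives 1810 nM, a number that sits alongside that of compound 1, the step of a 1.0-fold lower number from compound 1 to compound 2 (0.01 log units; within the scatter) being within the scatter. Compound 3 `COc1cc(-c2cc(/C=C/C(=O)c3ccc(F)c(F)c3)[nH]n2)cc(OC)c1OC` differs from compound 2 by 3,4-difluorophenyl in place of 4-methoxyphenyl on a carbonyl carbon. Going by the values given here, the only measured step, from compound 1 to compound 2, changed the group on the same aromatic ring and moved the number by a 1.0-fold lower number from compound 1 to compound 2 (0.01 log units; within the scatter), so a change on this ring has so far produced no step beyond the scatter. Compound 3 is therefore expected to give about 2000 nM (range 800 nM to 5000 nM), a step of a 1.1-fold higher number from compound 2 to compound 3 (0.04 log units; within the scatter) that is not expected to exceed the scatter.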

Compound 3, concentration for 50% growth inhibition: 3370 nM
For compound 3 the middle estimate is 1.7-fold (0.23 log units) below the measured one, within the range that was stated.
By their numbers in this assay, from the lowest: compounds 2, 1 and 3 (each within the scatter of the next).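

Replacing the whole aryl group on the carbonyl carbon with 3,4-difluorophenyl, which has no hydrogen-bond acceptor or donor, still gives no step beyond the scatter in this assay (a 1.9-fold higher number from compound 2 to compound 3 (0.27 log units; within the scatter); a 1.8-fold higher number from compound 1 to compound 3 (0.26 log units; within the scatter)). The tolerance seen so far therefore extends from the amino-for-methoxy exchange to a fluorinated ring, though the compounds remain too close to rank. Nothing measured here bears on why these numbers lie so close. Going by these compounds, it remains open whether a carboxylic acid on this ring, or a morpholine in place of the ring, would produce a step beyond the scatter.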